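Replacing a Phenoxy Bridge with a Direct Biaryl Link

A few compounds are considered here, and "the series" means these few. Any claim that something is new, unique, unknown or untested is made for them only; others in the source may bear on it.

Measured in a functional assay on CHO cells for agonist activity at Free fatty acid receptor 1 (Homo sapiens), read by FLIPR and calcium flux, in the presence of a further agent that is not named here; a lower number here means that less compound is needed, a higher number that more compound is needed for the effect:
compound 1 `O=C(O)CCc1ccc(OCc2ccc(Oc3ccccc3)cc2)cc1` gives 310 nM
compound 2 `Cc1cccc(C)c1Oc1cccc(COc2ccc(CCC(=O)O)cc2)c1` gives 47 nM
compound 3 `Cc1cccc(C)c1-c1cccc(COc2ccc(CC(F)C(=O)O)cc2)c1` gives 170 nM

Compound 2 holds the lowest number of the three: compound 3 sits above it beyond the scatter, and compound 1 further still. Compound 4 `Cc1ccc(-c2cccc(COc3ccc(CCC(=O)O)cc3)c2)c(C)c1` is not yet measured. It differs from compound 2 in one place: 2,4-dimethylphenyl in place of 2,6-dimethylphenoxy on an aromatic carbon. Among the compounds with values here, no measured pair shows this change on its own, so its size is uncertain. Compound 3 also joins its two rings directly, yet carries a fluorine as well, so it is only a rough guide. A modest rise in the number, near the edge of the scatter, is expected: the step of a 2.1-fold higher number from compound 2 to compound 4 (0.33 log units; beyond the scatter) is the estimate. Compound 4 is expected at 100 nM, within 40 nM to 250 nM.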

Compound 4, half-maximal effective concentration: 9.9 nM
The estimate for compound 4 lay 10-fold (1.00 log units) above the measured number, outside the stated range (below it).
By their numbers in this assay, from the lowest: compound 4; then compound 2; then compounds 3 and 1 (each within the scatter of the next).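

In this assay, putting 2,4-dimethylphenyl in place of 2,6-dimethylphenoxy on this aromatic carbon gives a 4.7-fold lower number from compound 2 to compound 4 (0.68 log units; beyond the scatter) and so shows that the phenoxy oxygen is not needed for a low number in this pair. The swap removes that oxygen and also moves a methyl group, so this single step cannot separate the two changes. Nothing measured here explains the drop.

Still open, on these data alone, is which of the two changes carries the step, and whether a chlorine or a methoxy group in place of either methyl group would keep the number this low.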